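Methoxy in place of trifluoromethyl on a benzyl hydroxamic acid

The compounds below may be only part of what the source reports. "The series", "measured", "known", "first", "only" and "open" are said of these compounds alone.

Measured compounds, each with its result in a functional assay on PC-3 cells (Homo sapiens) for antiproliferative activity; on this read-out higher numbers stand for weaker inhibition of growth and lower numbers for stronger inhibition of growth:
Compound 1, `O=C(CCC1=CCN(Cc2ccc(C(F)(F)F)cc2)C1=O)NO`, gives 4360 nM.
Compound 2, `O=C(CCC1=CCN(Cc2cccc(C(F)(F)F)c2)C1=O)NO`, gives 880 nM.
Compound 3, `COc1cccc(CCCN2CC=C(CCC(=O)NO)C2=O)c1`, gives 2590 nM.

Among these three, compound 1 carries the highest number in this assay. Compound 3 lies nearest to it, separated by a gap that stays within the usual scatter, so the two cannot be told apart on this read-out. Compound 2 lies furthest away, with a lower number that falls beyond the scatter.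

The unmeasured compound 4, `COc1ccc(CN2CC=C(CCC(=O)NO)C2=O)cc1`, differs from compound 1 in a single place: methoxy in place of trifluoromethyl on an aromatic carbon. Among the measured compounds shown here, no pair of measured compounds shows this exchange, so the size of its effect is unknown. For the measured compounds named here, compound 3, the only measured compound that carries a methoxy group, gives a number close to that of compound 1, which offers no sign of a large move in either direction. The step from compound 1 to compound 4 is therefore expected to be a 1.5-fold lower number from compound 1 to compound 4 (0.16 log units; within the scatter), that is, none beyond the scatter. Compound 4 is estimated at 3000 nM, within a range from 1000 nM to 9000 nM.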

Compound 4, concentration for 50% growth inhibition: 3120 nM
Compound 4: the middle estimate sits 1.0-fold (0.02 log units) below what was measured; measured number inside the range.
By their numbers in this assay, from the lowest: compound 2; then compounds 3, 4 and 1 (each within the scatter of the next).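

In this assay, the exchange gives a 1.4-fold lower number from compound 1 to compound 4 (0.15 log units; within the scatter), so compound 1 and compound 4 cannot be told apart on this read-out. Among the compounds shown here, at this carbon, para to a large group, going from four heavy atoms to two and from no hydrogen-bond acceptor to one therefore leaves no detectable mark on growth inhibition, a direct reading that no earlier pair of compounds offered. No measured information is available on what lies behind this outcome.

From the compounds shown here alone, it remains open whether an amine, a carboxylic acid or a nitrile on this same carbon would also stay within the scatter of compound 1. Going by these compounds, it is equally open whether methoxy would behave the same way at the ring position that holds trifluoromethyl in compound 2.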